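Adding a Hydroxy Group: Expected Effect on Permeability

The compounds below may be only part of what the source reports. "The series", "measured", "known", "first", "only" and "open" are said of these compounds alone.

Compound 1, `Oc1ccc2cc(-c3ccc4cccc(O)c4n3)oc2c1`, and compound 2, `Oc1cc(O)c2cc(-c3ccc4cccc(O)c4n3)oc2c1`, were both tested in an ADME assay for permeability, using PAMPA, with a stated time of 10 h, tested at 100 ug/mL; a higher number here means that the compound crosses the layer faster, a lower number that the compound crosses the layer more slowly. Compound 1 gives 15.8 10^-6 cm/s, and compound 2 gives 13.3 10^-6 cm/s. The structural change between them is hydroxy in place of hydrogen on an aromatic carbon, and it produced a 1.2-fold lower number from compound 1 to compound 2 (0.07 log units; within the scatter).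

Compound 3, `Oc1c(Cl)cc(-c2cc3ccccc3o2)c2cccnc12`, gives 2.6 10^-6 cm/s in this assay. How the core of compound 3 differs from the core of compound 1 is not broken down here.

Compound 4, `Oc1c(Cl)cc(-c2cc3cccc(O)c3o2)c2cccnc12`, carries hydroxy in place of hydrogen on an aromatic carbon. This is the same kind of change as in the first pair, although there the place was also meta to a hydroxy group, which is not so in compound 4. The earlier step of a 1.2-fold lower number from compound 1 to compound 2 (0.07 log units; within the scatter) stayed within the scatter. On that basis the step of a 1.2-fold lower number from compound 3 to compound 4 (0.07 log units; within the scatter) is expected to be small as well. Compound 4 is therefore estimated at 2.2 10^-6 cm/s, with a likely range from 1.2 10^-6 cm/s to 4 10^-6 cm/s.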

Compound 4, apparent permeability: 16.4 10^-6 cm/s
For compound 4 the middle estimate is 7.5-fold (0.87 log units) below the measured one, and the stated range ends below it.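

Hydroxy in place of hydrogen on an aromatic carbon gave a 6.3-fold higher number from compound 3 to compound 4 (0.80 log units; beyond the scatter) in this assay and so did not repeat the small step of the first pair, which shows that this change can behave differently on two cores in this series: the same change on two cores in this assay, a 1.2-fold lower number (0.07 log units; within the scatter) from compound 1 to compound 2 and a 6.3-fold higher number (0.80 log units; beyond the scatter) from compound 3 to compound 4, 7.5-fold (0.87 log units) apart, beyond the scatter of two such steps

The size of the step on one core is therefore a poor guide to its size on the other. What sets the two steps apart is not shown: the pairs differ both in their cores and in where the hydroxy sits, and two pairs give no rule for further cores.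

The compounds shown leave open whether another group at the same place on the core of compound 3, such as an amine or a methoxy group, would give a step like that of hydroxy. They also leave open what hydroxy would do at other places on that core.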